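The source may hold more compounds than are shown below. What is called first, only, known or untested is meant among the compounds shown, and "the series" means these compounds.

Within the data shown here, in a toxicity assay on NIH3T3 cells (Mus musculus) for cytotoxicity, read by resazurin assay (on this read-out higher numbers stand for an effect only at larger amounts of compound and lower numbers for an effect already at smaller amounts), compound 3 `O=[N+]([O-])c1ccc(Cn2cncc2CNc2cccc(-c3ccccc3)c2)cc1` gives 10000 nM, the only exact number among the three compounds measured so far. Compound 1 `Clc1ccc(NCc2cncn2Cc2ccc(-c3ccccc3)cc2)cc1-c1ccccc1` is reported only as a limit, > 1000 nM. Compound 2 `COC(=O)c1ccc(NCc2cncn2Cc2ccc([N+](=O)[O-])cc2)cc1-c1ccccc1` is also reported only as a limit, > 10000 nM.

The next compound, compound 4 `Clc1ccc(Cn2cncc2CNc2cccc(-c3ccccc3)c2)cc1`, has chloro in place of nitro on an aromatic carbon, para to a large group: chloro in place of nitro on an aromatic carbon. Among the measured compounds shown here, the one measured step, a number no higher from compound 2 to compound 3 (the limit leaves the size open), is a different exchange at a different place, and its size cannot be read. For the measured compounds named here, it therefore gives no size to carry over, and no measured step covers the loss of nitro. The expectation thus rests on compound 3 at 10000 nM, with no shift beyond the usual scatter in this assay and no direction favoured. The expected step, a 1.3-fold lower number from compound 3 to compound 4 (0.10 log units; within the scatter), is correspondingly small. For compound 4 the estimated value is 8000 nM, with an expected range from 2500 nM to 25000 nM.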

Compound 4, half-maximal effective concentration: 10000 nM
Beside the measured number, compound 4's estimate is 1.3-fold (0.10 log units) below it; the range from low to high includes it.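

In this assay the exchange of 4-nitrophenyl for 4-chlorophenyl gives no change at the digits printed from compound 3 to compound 4 (within the scatter), the first step among these compounds whose size can be read. At this place, para to a large group, the number of compound 3 therefore does not depend on nitro: chloro, with a single heavy atom and no hydrogen-bond acceptors, stands in its place and the printed value stays the same. Nothing at hand gives a reason for this outcome.

The compounds shown leave open whether an amine or a carboxylic acid at this same place would also leave the number where it stands. The earlier step that removes methoxycarbonyl still cannot be read, as the value of compound 2 is only a limit.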